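A few compounds are considered here, and "the series" means these few. Any claim that something is new, unique, unknown or untested is made for them only; others in the source may bear on it.

Notes on the series. Compound 1 `COc1cc2c(/C=C3/C(=O)Nc4ccc(Cl)cc43)c(Cl)n(Cc3cc(OC)c(OC)c(OC)c3)c2cc1C` and compound 2 `COc1cc2c(/C=C3/C(=O)Nc4cccc(Cl)c43)c(Cl)n(Cc3cc(OC)c(OC)c(OC)c3)c2cc1C` share a core bearing a trimethoxybenzyl group on the ring nitrogen; compound 3 `COc1c(/C=C2/C(=O)Nc3ccccc32)c2ccccc2n1-c1ccccc1` carries a phenyl there instead. In a functional assay on cells (Cancer cell lines, Homo sapiens) for cytotoxicity, with a stated time of 48 h (a lower number here means a stronger inhibitor of growth, a higher number a weaker inhibitor of growth), compound 1 gives 3890 nM. Compound 2 gives 5130 nM and compound 3 gives 3470 nM. Among these three numbers compound 1 stands second highest; its value and that of compound 3 lie within the scatter of one another, and the step of a 1.3-fold higher number from compound 1 to compound 2 (0.12 log units; within the scatter) is also within the scatter, so nothing in the set so far separates the three beyond the noise of the measurement.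

Compound 4 `COc1ccc2c(c1)/C(=C\c1c(Cl)n(Cc3cc(OC)c(OC)c(OC)c3)c3cc(C)c(OC)cc13)C(=O)N2` differs from compound 1 by methoxy in place of chloro on an aromatic carbon. Among the measured compounds shown here, no measured step bears directly on this exchange: the only step at hand, a 1.3-fold higher number from compound 1 to compound 2 (0.12 log units; within the scatter), concerns a different placement of the same chloro rather than its replacement, and it was within the scatter. With no comparable exchange measured, the expectation for compound 4 is a step no larger than the scatter, a 1.0-fold higher number from compound 1 to compound 4 (0.01 log units; within the scatter). Compound 4 is therefore estimated at 4000 nM, with a range from 1500 nM to 11000 nM.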

Compound 4, concentration for total growth inhibition: 95500 nM
Compound 4: the middle estimate sits 24-fold (1.38 log units) below what was measured, and the stated range ends below it.
By their numbers in this assay, from the lowest: compounds 3, 1 and 2 (each within the scatter of the next); then compound 4.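

In this assay the aromatic carbon carrying the chloro of compound 1 is not indifferent to what stands on it: the exchange for methoxy gives a 25-fold higher number from compound 1 to compound 4 (1.39 log units; beyond the scatter) while moving the chloro gives only a 1.3-fold higher number from compound 1 to compound 2 (0.12 log units; within the scatter) in the same series. Among the compounds shown here, this exchange is the first single change here to separate two compounds beyond the scatter. Nothing measured here accounts for the step.

A single exchange cannot tell whether the departing chloro or the entering methoxy carries the step. A methyl or a bare hydrogen at this place would separate those two readings, and an ethoxy would show whether the step goes further with a longer chain on the oxygen.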